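Oxime series: fluoro for chloro on compound 1

The source may report more compounds than this note shows. Statements on the series, on what has been measured and on what is new or still open speak of the compounds shown alone.

Among the measured compounds shown here, compound 1 `O/N=C(\C=C\c1ccc(Cl)cc1)c1ccc(Cl)cc1` gives 14100 nM in an ADME assay on cells (Mus musculus, strain Balb/c) for cytotoxicity, read by MTT assay, with a stated time of 48 h (on this read-out higher numbers stand for lower toxicity in this test and lower numbers for higher toxicity in this test), and holds the lowest of the two numbers measured so far; the nearest is compound 2 `COc1ccc(/C=C/C(=N\O)c2ccc(Cl)cc2)cc1`, which gives 24300 nM. For the measured compounds named here, the one measured step, a 1.7-fold higher number from compound 1 to compound 2 (0.24 log units; within the scatter), lies within the scatter. Compound 3 `O/N=C(\C=C\c1ccc(Cl)cc1)c1ccc(F)cc1` differs from compound 1 by fluoro in place of chloro on an aromatic carbon. Going by the values given here, no measured step touches this part of the core, and the single step in hand stayed within the scatter, so nothing beyond the scatter is expected here either. Compound 3 is therefore expected at 14000 nM, between 6000 nM and 32000 nM, meaning a 1.0-fold lower number from compound 1 to compound 3 (0.00 log units; within the scatter).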

Compound 3, half-maximal cytotoxic concentration: 14800 nM
Compound 3: middle estimate off by 1.1-fold (0.02 log units), on the low side; the range from low to high includes it.
By their numbers in this assay, from the lowest: compounds 1, 3 and 2 (each within the scatter of the next).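

Fluoro in place of chloro at this position, on an aromatic carbon para to a large group, gives a 1.0-fold higher number from compound 1 to compound 3 (0.02 log units; within the scatter) in this assay. Among the compounds shown here, this is the first reading for this position, and exchanging one halogen for the other here leaves the number within the scatter. No evidence on hand bears on this result.

The compounds shown leave open whether a non-halogen group here, such as an amine or a carboxylic acid, would move the number beyond the scatter. They also leave open whether a step of any kind in this series can exceed the scatter in this assay.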